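A few compounds are considered here, and "the series" means these few. Any claim that something is new, unique, unknown or untested is made for them only; others in the source may bear on it.

Compound 1, `Oc1ccc(NC(=S)Nc2ccc3[nH]ccc3c2)cc1`, sets the starting point in an ADME assay on cells for inhibition of Amine oxidase [flavin-containing] A (Homo sapiens), read by spectrophotometry (a higher number here means a weaker inhibitor, a lower number a stronger inhibitor), where compound 1 returns only a limit, > 100000 nM. Among the compounds with values here, compound 2, `Oc1ccc(NC(=S)Nc2ccc3[nH]ccc3c2)cc1Cl`, bears a chloro on an aromatic carbon, and in this assay compound 2 gives 58000 nM, the single real number among the values measured so far. Within the data shown here, the step of an at least 1.7-fold lower number from compound 1 to compound 2 (0.23 log units; that floor lies within the scatter) is the only measured comparison, and its floor is set by the limit of > 100000 nM in this assay, at which 1 of the 2 values shown sits, rather than by a second number.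

Compound 3, `COC(=O)c1cc(NC(=S)Nc2ccc3[nH]ccc3c2)ccc1O`, differs from compound 2 by methoxycarbonyl in place of chloro on an aromatic carbon. Among the measured compounds shown here, no measured step involves a methoxycarbonyl, and the one known step, an at least 1.7-fold lower number from compound 1 to compound 2 (0.23 log units; that floor lies within the scatter), was at its floor small; so compound 3 is expected to stay in the same weak region of this assay, with an estimated step of a 1.4-fold higher number from compound 2 to compound 3 (0.14 log units; within the scatter). Compound 3 is therefore estimated at 80000 nM, with a range from 25000 nM to 300000 nM.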

Compound 3, half-maximal inhibitory concentration: > 100000 nM
Compound 3: no number, only a limit (the forecaster's own chance of this, stated with the estimate: 40%); middle value at least 1.2-fold (0.09 log units) from the limit.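

In this assay, methoxycarbonyl in place of chloro on this aromatic carbon, ortho to a hydroxy group, gives an at least 1.7-fold higher number from compound 2 to compound 3 (0.23 log units; that floor lies within the scatter), so this larger group, with its two hydrogen-bond acceptors, brings no measurable gain at this position. The step between compound 1 and compound 3 cannot be read, as both values are limits, so neither hydrogen nor methoxycarbonyl at this position can be placed relative to the other. Within the data shown here, compound 2 remains the only compound with a real number, and the picture at this position now rests mainly on a limit: the limit of > 100000 nM in this assay, at which 2 of the 3 values shown sit.

As far as these compounds go, how far compound 1 and compound 3 actually lie from that limit stays open. So does whether an amine, a carboxylic acid or a methyl group on this same carbon would return a real number at all.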